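Swapping the triazole substituent in a cytotoxic furanone series

A few compounds are considered here, and "the series" means these few. Any claim that something is new, unique, unknown or untested is made for them only; others in the source may bear on it.

Three compounds share a furanone core carrying two benzyloxy groups and a triazole-bearing side chain, and all were tested in an ADME assay on HFF cells (Homo sapiens) for cytotoxicity, read by MTT assay, with a stated time of 72 h; a higher number here means a weaker inhibitor, a lower number a stronger inhibitor. Compound 1 `O=C1O/C(=C\Cn2cc(-c3cc(F)cc(F)c3)nn2)C(OCc2ccccc2)=C1OCc1ccccc1` gives > 100000 nM, which is a limit of the assay and not a number; this is the limit of > 100000 nM in this assay, at which 1 of the 3 values shown sits. Compound 2 `CC(C)(C)OC(=O)N1CCN(C(=S)SCc2cn(C[C@H](O)[C@H]3OC(=O)C(OCc4ccccc4)=C3OCc3ccccc3)nn2)CC1` gives 60 nM in this assay. Compound 3 `COc1ccccc1-c1cn(C[C@H](O)[C@H]2OC(=O)C(OCc3ccccc3)=C2OCc2ccccc2)nn1` gives 50 nM in this assay. Among the two numerical values, compound 3 and compound 2 sit within the usual scatter of each other, although they carry quite different groups on the triazole ring.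

Compound 4 `O=C1O[C@H]([C@@H](O)Cn2cc(CNS(=O)(=O)c3ccc(Cl)cc3)nn2)C(OCc2ccccc2)=C1OCc1ccccc1` has not yet been measured in this assay. It keeps the hydroxyl-bearing side chain found in compound 2 and compound 3, and differs from compound 3 only by (((4-chlorophenyl)sulfonyl)amino)methyl in place of 2-methoxyphenyl on an aromatic carbon. Among the compounds with values here, no measured pair shows the effect of changing this group alone, but the closeness of compound 2 at 60 nM and compound 3 at 50 nM suggests the triazole substituent matters little here. Compound 4 is therefore expected to give about 80 nM, in a range from 20 nM to 400 nM. The expected step is a 1.6-fold higher number from compound 3 to compound 4 (0.20 log units; within the scatter), estimated to stay within the scatter.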

Compound 4, half-maximal inhibitory concentration: 20 nM
For compound 4 the middle estimate is 4.0-fold (0.60 log units) above the measured one; low and high end bracket the measured number.
By their numbers in this assay, from the lowest: compound 4; then compounds 3 and 2 (each within the scatter of the next). At a limit, above all of these: compound 1.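

In this assay, the position on the aromatic carbon of the five-membered aromatic ring with 3 nitrogen responds to a change of group: (((4-chlorophenyl)sulfonyl)amino)methyl in place of 2-methoxyphenyl gives a 2.5-fold lower number from compound 3 to compound 4 (0.40 log units; beyond the scatter), a modest step, but one that lies beyond the usual scatter. Within the data shown here, this is the first pair in the set for which a step at this position can be read, so a lower number here is now tied directly to a single change of group. The entering group brings a sulfur, a nitrogen, a chlorine and a hydrogen-bond donor that the leaving group lacks, but nothing measured here shows which of these parts accounts for the step.

The compounds shown leave open whether the chlorine, the sulfonyl unit or the methyl link matters most, which a plain phenylsulfonyl version without the chlorine or a simple aminomethyl group at the same position could help separate. They also leave open how a carboxylic acid or a longer chain at this position would read in this assay.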